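Phenoxy in place of chloro on the aryl ring

The source may report more compounds than this note shows. Statements on the series, on what has been measured and on what is new or still open speak of the compounds shown alone.

Compound 1 `CS(=O)(=O)c1ccc(N2N=C(c3ccc(Br)cc3)CCC2=O)cc1` gives 31.5% in a functional assay on the whole organism (strain Wistar) for inhibition, with Rattus norvegicus as the target, read by paw edema, with stated times of 30 min and 5 h, at a dose of 0.05 mmol/kg by the oral route; a higher number here means more inhibition at the dose given (going by the name of the read-out), a lower number less inhibition. Compound 2 `CS(=O)(=O)c1ccc(N2N=C(c3ccc(Cl)cc3)CCC2=O)cc1` gives 36.8% in this assay; the step of a number 5.3 percentage points higher from compound 1 to compound 2 (within the scatter) lies within the scatter, so the two compounds stand together on the numbers shown, with nothing separating them. Compound 3 `CS(=O)(=O)c1ccc(N2N=C(c3ccc(Oc4ccccc4)cc3)CCC2=O)cc1` carries phenoxy in place of chloro on an aromatic carbon. Among the measured compounds shown here, the only measured step exchanges one halogen for another and says nothing about a phenoxy group, so no basis exists for a step beyond the scatter in either direction. Compound 3 is therefore expected near compound 2, at 35% with a range of 15% to 55%, the expected step being a number 1.8 percentage points lower from compound 2 to compound 3 (within the scatter).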

Compound 3, a percentage reported as inhibition, in the whole organism at one dose (the size of the read-out at that dose, not a potency): 65.7%
The estimate for compound 3 lay 30.7 percentage points below the measured number; the whole stated range lies below it.
By their numbers in this assay, from the lowest: compounds 1 and 2 (each within the scatter of the next); then compound 3.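

In this assay phenoxy in place of chloro gives a number 28.9 percentage points higher from compound 2 to compound 3 (beyond the scatter) and phenoxy in place of bromo gives a number 34.2 percentage points higher from compound 1 to compound 3 (beyond the scatter). The group on this aromatic carbon, para to a large group, can therefore move the read-out beyond the scatter, which the exchange of one halogen for the other did not do. Nothing available bears on the reason for this rise.

As far as these compounds go, whether the rise follows the oxygen link or the added aromatic ring stays open: a directly attached phenyl or a methoxy group would separate the two. Also open, from the compounds shown here alone, is the effect of a fluoro or an amine on the phenoxy ring.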